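A few compounds are considered here, and "the series" means these few. Any claim that something is new, unique, unknown or untested is made for them only; others in the source may bear on it.

The measured compounds:
Compound 1, `COc1ccc(C(=O)/C=C/c2cc(OC)c(OC)c(OC)c2)c2c1C=CC(C)(C)O2`, in a functional assay on HepG2 cells (Homo sapiens) for antiproliferative activity, read by MTT assay, with a stated time of 24 h; a lower number here means a stronger inhibitor, a higher number a weaker inhibitor: > 10000 nM
Compound 2, `COc1ccc(C(=O)/C=C/c2cccc(F)c2)c2c1C=CC(C)(C)O2`, in this assay: > 10000 nM

In this assay compound 1 gives > 10000 nM, which is a limit of the assay and not a number. In the same assay compound 2 gives > 10000 nM, again a limit. Compound 1 therefore stands at the limit of > 10000 nM in this assay, at which 2 of the 2 values shown sit, and nothing in the data separates it from compound 2, as neither has a number. Compound 3, `COc1cc(/C=C/C(=O)c2ccc(OC)c3c2OC(C)(C)C=C3)cc(OC)c1O`, has not yet been measured in this assay. It differs from compound 1 in one place: hydrogen in place of methyl on an oxygen on an aromatic ring, or, read one bond further out, methoxy to hydroxy. Among the measured compounds shown here, no measured step between two compounds addresses a change of this kind, so no size or direction can be read from the data; no movement beyond the scatter is expected. Compound 3 is expected to give about 15000 nM in this assay, estimated to lie between 3000 nM and 60000 nM, and most likely to be reported only as a limit again. The expected step that the limit leaves unreadable from compound 1 to compound 3 is thus an estimate of no real change.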

Compound 3, half-maximal inhibitory concentration: > 10000 nM
Compound 3: only a limit was reported (the forecaster's own chance of this, stated with the estimate: 70%); the middle value lies beyond the limit too.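

In this assay compound 3 gives > 10000 nM as a limit of the assay and not a number. Compound 1 also has only a limit, so the change from methoxy to hydroxy between the two cannot be read: the limit of > 10000 nM in this assay, at which 3 of the 3 values shown sit. The compounds shown leave open whether in this assay any change on the shared core gives a readable value at all.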